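Capping the Amine: Expectations for a Benzyloxycarbonyl Derivative

The compounds below may be only part of what the source reports. "The series", "measured", "known", "first", "only" and "open" are said of these compounds alone.

Compound 1 `COC(=O)CNC(=O)C(CSCc1ccc(Br)cc1)NC(=O)CCC(N)C(=O)OC` was tested in a functional assay on K562 cells (Homo sapiens) for cytotoxicity; on this read-out higher numbers stand for weaker inhibition and lower numbers for stronger inhibition. In this assay compound 1 gives > 50 uM, which is a limit of the assay rather than a measured number. Among the measured compounds shown here, a second member of the set, compound 2 `O=CNC(CCC(=O)NC(CSCc1ccc(Br)cc1)C(=O)NCC(=O)O)C(=O)O`, differs from compound 1 in several places at once, so no single step between the two is drawn. In this assay compound 2 gives > 50 uM, again a limit and not a number. Compound 1 therefore stands at the limit of > 50 uM in this assay, at which 2 of the 2 values shown sit, and neither measured compound shows inhibition that the assay could put a number on.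

Compound 3 `COC(=O)CNC(=O)C(CSCc1ccc(Br)cc1)NC(=O)CCC(NC(=O)OCc1ccccc1)C(=O)OC` has not yet been measured. It differs from compound 1 by benzyloxycarbonyl in place of hydrogen on an amine nitrogen. For the measured compounds named here, no measured step in this assay ties such a change to a shift in the read-out, so no direction can be read from the data. Because compound 1 sits at the limit of > 50 uM in this assay, at which 2 of the 2 values shown sit, the step from compound 1 to compound 3 is expected to be a step that the limit leaves unreadable from compound 1 to compound 3, that is, nothing beyond the scatter. Compound 3 is expected to give about 80 uM, within 30 uM to 300 uM, and most probably only a limit once more.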

Compound 3, concentration for 50% inhibition: 16.7 uM
For compound 3 the middle estimate is 4.8-fold (0.68 log units) above the measured one; measured number outside the range, below it.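

Placing benzyloxycarbonyl on the amine nitrogen brings the first change in this set that can be read in this assay: an at least 2.9-fold lower number from compound 1 to compound 3 (0.47 log units; beyond the scatter). Among the compounds shown here, on this read-out a lower number stands for stronger inhibition, so this nitrogen is a place where a large group is tolerated and where the read-out can move in the favourable direction, something the earlier compounds, with no number to compare, could not show. The true size of the step may be larger than the printed one, because the starting value of compound 1 is a limit of the assay and not a number: the limit of > 50 uM in this assay, at which 2 of the 3 values shown sit.

As far as these compounds go, what remains open is which part of the change matters, whether it is the loss of the free amine, the carbonyl-bearing cap or the six-membered aromatic ring that the new group carries, and the data give no measured property that would explain the shift. A small acetyl group or a plain benzyl group on the same nitrogen would help to separate these parts, and neither is among the compounds shown.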